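The source may hold more compounds than are shown below. What is called first, only, known or untested is meant among the compounds shown, and "the series" means these compounds.

Compound 2 `O=S(=O)(NCCCNCc1ccccc1)c1cc(C(F)(F)F)cc(C(F)(F)F)c1` is the unsubstituted benzyl member of the series. In a functional assay on Capan-2 cells (Homo sapiens) for inhibition, read by MTT assay, with a stated time of 72 h (on this read-out lower numbers stand for stronger inhibition of growth and higher numbers for weaker inhibition of growth), compound 2 gives 14000 nM. Compound 1 `O=S(=O)(NCCCNCc1ccc(Cl)c(C(F)(F)F)c1)c1cc(C(F)(F)F)cc(C(F)(F)F)c1` gives 9100 nM in this assay, and the two numbers lie within the scatter of each other, as the step of a 1.5-fold higher number from compound 1 to compound 2 (0.19 log units; within the scatter) shows. Compound 3 `O=S(=O)(NCCCNCc1ccc(Cl)cc1)c1cc(C(F)(F)F)cc(C(F)(F)F)c1` differs from compound 2 by chloro in place of hydrogen on an aromatic carbon. Within the data shown here, only that single step bears on this change; it covers a larger exchange on the benzyl group and still stays within the scatter. A step no larger than the scatter is therefore expected, a 1.3-fold lower number from compound 2 to compound 3 (0.10 log units; within the scatter). For compound 3 the estimate in this assay is 11000 nM, range 5000 nM to 25000 nM.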

Compound 3, concentration for 50% growth inhibition: 2700 nM
Compound 3: middle estimate off by 4.1-fold (0.61 log units), on the high side, and the stated range ends above it.
By their numbers in this assay, from the lowest: compound 3; then compounds 1 and 2 (each within the scatter of the next).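

The 4-chloro group alone gives a step beyond the scatter in this assay (a 5.2-fold lower number from compound 2 to compound 3 (0.71 log units; beyond the scatter)). Compound 1 carries the same chloro with a trifluoromethyl group as well, and hydrogen in place of that trifluoromethyl also gives a step beyond the scatter (a 3.4-fold lower number from compound 1 to compound 3 (0.53 log units; beyond the scatter)), so the gain from chloro at this place depends on what else the aromatic ring carries. No evidence on the origin of these steps is at hand. From the compounds shown here alone, whether fluoro, bromo or methoxy at this place gives a similar step remains open, as does the effect of trifluoromethyl alone on the benzyl group.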